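Compound 2 to compound 3: cyclopropyl in place of methyl

A few compounds are considered here, and "the series" means these few. Any claim that something is new, unique, unknown or untested is made for them only; others in the source may bear on it.

Measured so far in a functional assay on the whole organism for inhibition, with Mus musculus as the target; a higher number here means that more compound is needed for the effect, a lower number that less compound is needed:
compound 1 `Cc1nnc(CNC(=O)CN)n1-c1ccc(Cl)cc1C(=O)c1ccccc1F`: 1.52 mg/kg
compound 2 `Cc1nnc(CNC(=O)CN)n1-c1ccc(Cl)cc1C(=O)c1ccccc1Cl`: 0.31 mg/kg

Of the two measured compounds, compound 2 has the lower number at 0.31 mg/kg. The next compound to be measured is compound 3 `NCC(=O)NCc1nnc(C2CC2)n1-c1ccc(Cl)cc1C(=O)c1ccccc1Cl`, with cyclopropyl in place of methyl on an aromatic carbon. Among the measured compounds shown here, the only measured step, a 4.9-fold lower number from compound 1 to compound 2 (0.69 log units; beyond the scatter), is a chloro-for-fluoro exchange elsewhere in the molecule. For the measured compounds named here, no measured step covers the methyl position, so that step gives only a rough scale and no direction. A modest change in this assay is therefore expected, leaning slightly towards a higher number, though a result within the scatter would not be surprising. The expected step is a 1.6-fold higher number from compound 2 to compound 3 (0.21 log units; within the scatter). For compound 3 the estimate is 0.5 mg/kg, with an expected range of 0.15 mg/kg to 1.6 mg/kg.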

Compound 3, dose for half-maximal effect: 1.5 mg/kg
The estimate for compound 3 lay 3.0-fold (0.48 log units) below the measured number, within the range that was stated.
By their numbers in this assay, from the lowest: compound 2; then compounds 3 and 1 (each within the scatter of the next).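

Among the compounds shown here, with cyclopropyl in place of methyl, this assay gives a 4.8-fold higher number from compound 2 to compound 3 (0.68 log units; beyond the scatter), the first measured step at this position on an aromatic carbon between two ring nitrogen atoms. The position is therefore not indifferent to its group: of the two groups seen here, methyl goes with less compound needed, and the step lies beyond the scatter. Nothing measured on these compounds bears on why the number rises, so the step stands as an observation only.

With one pair at this position, the compounds shown give no trend, and it remains open whether an ethyl group, an isopropyl group or a plain hydrogen would give a number closer to compound 2 or to compound 3. Also open, on these data alone, is whether the same exchange would give a step of similar size on compound 1, which carries fluoro instead of chloro.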